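Propoxy in Place of Nitrophenoxy on the Aryl Ring

The source may hold more compounds than are shown below. What is called first, only, known or untested is meant among the compounds shown, and "the series" means these compounds.

Compound 1 `CCOc1ccc([C@@H]2CC(=O)c3cc(CC=C(C)C)c(OC)cc3O2)cc1` — a functional assay on HCT-116 cells (Homo sapiens) for inhibition, read by sulforhodamine B assay, with a stated time of 48 h, tested at 50 uM; on this read-out lower numbers stand for less inhibition of growth and higher numbers for more inhibition of growth at the one concentration tested: 65%
Compound 2 `COc1cc2c(cc1CC=C(C)C)C(=O)C[C@@H](c1ccc(Oc3cccc([N+](=O)[O-])c3)cc1)O2` — this assay: 46%
Compound 3 `COc1ccc([C@@H]2C/C(=N/OCc3cn(-c4cccnc4Cl)nn3)c3cc(CC=C(C)C)c(OC)cc3O2)cc1` — this assay: 47%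

Compound 2 stands at the low end of the three numbers in this assay. Compound 3 lies within the scatter of it, while compound 1 sits beyond the scatter above it. The shared core is kept throughout; the compounds differ only in the group on the oxygen of the aromatic ring.

The step to compound 4 `CCCOc1ccc([C@@H]2CC(=O)c3cc(CC=C(C)C)c(OC)cc3O2)cc1` is propyl in place of 3-nitrophenyl on an oxygen on an aromatic ring. Among the compounds with values here, the one measured step that bears on it is a number 19 percentage points lower from compound 1 to compound 2 (beyond the scatter), where 3-nitrophenyl replaced ethyl. The change to compound 4 removes the 3-nitrophenyl again and brings in propyl, a short chain close to the ethyl of compound 1. A step in this assay of about that size, but upward, is therefore expected, a number 16 percentage points higher from compound 2 to compound 4 (beyond the scatter). For compound 4 the estimate in this assay is 62%, with a range from 50% to 74%.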

Compound 4, percent growth inhibition at one concentration: 63%
The estimate for compound 4 lay 1 percentage points below the measured number; measured number inside the range.
By their numbers in this assay, from the lowest: compounds 2 and 3 (each within the scatter of the next); then compounds 4 and 1 (each within the scatter of the next).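

In this assay, the step of a number 17 percentage points higher from compound 2 to compound 4 (beyond the scatter) shows that the lower number of compound 2 is not recovered by ethyl alone, as propyl in place of 3-nitrophenyl on this oxygen also gives a step beyond the scatter. The step of a number 2 percentage points lower from compound 1 to compound 4 (within the scatter) lies within the scatter, so on this read-out the added methyl leaves the two short chains indistinguishable. No measurement shown here accounts for the gap between these chains and 3-nitrophenyl.

What the compounds shown leave open is how far the chain can grow, since a longer chain such as butyl or a chain carrying an amine has no number here. From the compounds shown here alone, it also remains open whether an unsubstituted phenyl on this oxygen would stand with compound 2 or with the short chains.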